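A Fluorophenyl in Place of the Sulfonyl Group

The compounds below may be only part of what the source reports. "The series", "measured", "known", "first", "only" and "open" are said of these compounds alone.

Compound 1 `COc1ccc2[nH]c(C(=O)N3CC(=O)N(Cc4ccccc4)[C@@H](CN4CCN(S(=O)(=O)c5ccccc5)CC4)C3)cc2c1` gives 16900 nM in a physicochemical assay for solubility, read by spectrophotometry, in phosphate buffer, with a stated time of 2 h, at pH 7.4 (a lower number here means a less soluble compound, a higher number a more soluble compound), the higher of the two measured numbers. Compound 2 `Cc1ccc2[nH]c(C(=O)N3CC(=O)N(Cc4ccccc4)[C@@H](CN4CCC5(CCC5)CC4)C3)cc2c1` gives 12300 nM in this assay, and the gap between the two lies within the scatter, so they cannot be ranked. Compound 3 `COc1ccc2[nH]c(C(=O)N3CC(=O)N(Cc4ccccc4)[C@@H](CN4CCN(c5ccc(F)cc5)CC4)C3)cc2c1` differs from compound 1 in one place: 4-fluorophenyl in place of phenylsulfonyl on an amine nitrogen in a ring. Among the compounds with values here, no measured pair shows this change, so its size is not known from the data. A modest downward step is expected, a 2.1-fold lower number from compound 1 to compound 3 (0.32 log units; beyond the scatter), though a result within the scatter would not surprise. Compound 3 is therefore estimated at 8000 nM, with a range from 3000 nM to 25000 nM.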

Compound 3, solubility: 20700 nM
Estimate against measurement, compound 3: 2.6-fold (0.41 log units) below; the range from low to high includes it.
By their numbers in this assay, from the lowest: compounds 2, 1 and 3 (each within the scatter of the next).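

In this assay the step of 4-fluorophenyl in place of phenylsulfonyl on an amine nitrogen in a ring comes to a 1.2-fold higher number from compound 1 to compound 3 (0.09 log units; within the scatter) and so cannot be read as a real difference. At this position, then, the phenylsulfonyl group with its 2 hydrogen-bond acceptors can give way to a group with none and leave the number unresolved from that of compound 1. Nothing shown here offers an explanation for this result.

Going by these compounds, it remains open whether a much smaller group on that nitrogen, such as methyl or acetyl, would also stay within the scatter. The same question holds for an aryl group carrying a carboxylic acid.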